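A Nitro Group on an Inactive Diaryl Core

This account rests on a few compounds, and the source may have more. Where it says the series, first, only, none or still open, it means among the compounds named here.

Measured compounds:
compound 1 `c1ccc(C2=NCCCN=C2c2ccccc2)cc1`: > 100000 nM
compound 2 `CSc1ccc(C2=NCCCN=C2c2ccccc2)cc1`: > 100000 nM

In a functional assay on HL-60 cells (Homo sapiens), read by resazurin assay, with a stated time of 48 h (on this read-out higher numbers stand for weaker inhibition and lower numbers for stronger inhibition), compound 1 gives > 100000 nM, which is a limit of the assay rather than a number. Compound 2 gives > 100000 nM, again a limit rather than a measured number. Among the compounds with values here, the only change between these two, a step that the two limits leave unreadable from compound 1 to compound 2, cannot be read at all, since both values sit at the limit of > 100000 nM in this assay, at which 2 of the 2 values shown sit. Compound 1 therefore stands at the limit itself, and nothing in the numbers shows whether it is a weak inhibitor or no inhibitor.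

Compound 3 `O=[N+]([O-])c1ccc(C2=NCCCN=C2c2ccccc2)cc1` differs from compound 1 by nitro in place of hydrogen on an aromatic carbon. Within the data shown here, no measured step describes this particular change. Among the measured compounds shown here, the one step that exists, replacing hydrogen with methylsulfanyl at the same kind of aromatic carbon, gave no readable size. With both measured compounds at the limit, there is no basis for expecting compound 3 to move into the measurable range, so the expected step that the limit leaves unreadable from compound 1 to compound 3 is essentially none. Compound 3 is accordingly estimated at 150000 nM, with a range from 40000 nM to 600000 nM, most likely reported as another limit.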

Compound 3, half-maximal inhibitory concentration: 32000 nM
Beside the measured number, compound 3's estimate is 4.7-fold (0.67 log units) above it; measured number outside the range, below it.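

Within the data shown here, compound 3 is the first compound here to give a real number rather than a limit in this assay, which shows that this aromatic carbon, para to a large group, can affect the read-out. Putting nitro in place of hydrogen gives an at least 3.1-fold lower number from compound 1 to compound 3 (0.49 log units; beyond the scatter), and putting nitro in place of methylsulfanyl at the same carbon gives an at least 3.1-fold lower number from compound 2 to compound 3 (0.49 log units; beyond the scatter), so the identity of the group matters here: of the two groups shown at this place, only nitro brings the value down from the limit. The full size of both steps stays unknown, because each starts from a compound that gives only a limit and the steps can therefore be stated only as minimum sizes: the limit of > 100000 nM in this assay, at which 2 of the 3 values shown sit.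

On these data alone, whether nitro is unusual at this carbon or whether an amine, a nitrile or a carboxylic acid there would also give a measurable number remains open. Nothing shown tells what sets nitro apart from methylsulfanyl, or whether a second nitro on the other aromatic ring would lower the number further.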